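This account rests on a few compounds, and the source may have more. Where it says the series, first, only, none or still open, it means among the compounds named here.

Compounds measured so far:
- compound 1 (`Oc1ccc2ccccc2c1C(Nc1nc2ccccc2s1)c1cn(-c2ccccc2)nc1-c1ccccc1`): 48900 nM
- compound 2 (`O=[N+]([O-])c1ccc(-c2nn(-c3ccccc3)cc2C(Nc2nc3ccccc3s2)c2c(O)ccc3ccccc23)cc1`): 14700 nM

Among the measured compounds shown here, in a functional assay on MCF7 cells (Homo sapiens) for antiproliferative activity, read by MTT assay, with a stated time of 48 h (a higher number here means a weaker inhibitor, a lower number a stronger inhibitor), compound 2 holds the lower of the two numbers, at 14700 nM, and its only neighbour is compound 1, at 48900 nM. The next compound, compound 3 (`Cc1ccc(-c2nn(-c3ccccc3)cc2C(Nc2nc3ccccc3s2)c2c(O)ccc3ccccc23)cc1`), keeps the core of compound 2 and alters one group: methyl in place of nitro on an aromatic carbon. In words, this is methyl in place of nitro on an aromatic carbon, the change from 4-nitrophenyl to 4-methylphenyl.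

For the measured compounds named here, only one measured step bears on this change: a 3.3-fold lower number from compound 1 to compound 2 (0.52 log units; beyond the scatter). There, nitro stood in place of hydrogen, and the step was modest but beyond the scatter. Going by the values given here, compound 3 removes that nitro but puts methyl rather than hydrogen in its place, and no measured compound carries methyl there, so the guide is only partial. With a 3.3-fold lower number from compound 1 to compound 2 (0.52 log units; beyond the scatter) as the sole reference, a move to a higher number of similar or slightly smaller size is expected in this assay. The expected change is a 2.4-fold higher number from compound 2 to compound 3 (0.38 log units; beyond the scatter). Compound 3 is estimated at 35000 nM, with an expected range of 14000 nM to 90000 nM.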

Compound 3, half-maximal inhibitory concentration: 13100 nM
Beside the measured number, compound 3's estimate is 2.7-fold (0.43 log units) above it; the measured number lies below the stated range.
By their numbers in this assay, from the lowest: compounds 3 and 2 (each within the scatter of the next); then compound 1.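

In this assay, replacing 4-nitrophenyl with 4-methylphenyl gives a 1.1-fold lower number from compound 2 to compound 3 (0.05 log units; within the scatter), so at this position the two groups cannot be told apart, although nitro carries hydrogen-bond acceptors and methyl carries none. Methyl in place of hydrogen gives a 3.7-fold lower number from compound 1 to compound 3 (0.57 log units; beyond the scatter), a step of much the same size as a 3.3-fold lower number from compound 1 to compound 2 (0.52 log units; beyond the scatter), which shows that the lower number seen with nitro is not specific to nitro: both compounds with a group on this aromatic carbon, para to a large group, sit beyond the scatter from the unsubstituted compound 1. No measurement is available to account for this shared step.

On these data alone, these three compounds compare only hydrogen, nitro and methyl at this one place, so it remains open whether an amine, a carboxylic acid or a longer chain such as butyl would stay level with compound 2 and compound 3 or move away from them. They also leave open whether the same replacement would behave alike elsewhere on the shared core.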